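The source may report more compounds than this note shows. Statements on the series, on what has been measured and on what is new or still open speak of the compounds shown alone.

Going by the values given here, compound 1, with the structure `Cn1cc(-c2ccc(NC(=O)c3cn(CC4CCOCC4)cc(-c4ccc(F)cc4)c3=O)c(F)c2)c2c(N)ncnc21`, is the stronger of the two compounds measured so far: in an assay on isolated protein for inhibition of tyrosine-protein kinase receptor UFO (Homo sapiens), read by ELISA (a lower number here means a stronger inhibitor, a higher number a weaker inhibitor), compound 1 gives 0.2 nM. Compound 2, with the structure `Cn1cc(-c2cc(F)c(NC(=O)c3cn(CC4CCOCC4)cc(-c4ccc(F)cc4)c3=O)cc2F)c2c(N)ncnc21`, carries one extra fluoro on an aromatic carbon, and in this assay compound 2 gives 0.5 nM; that is a 2.5-fold higher number from compound 1 to compound 2 (0.40 log units; beyond the scatter). Compound 1 therefore stands at the lowest number of the two.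

Compound 3, with the structure `Cn1cc(-c2ccc(NC(=O)c3cn(CC4CCOCC4)cc(-c4ccc(F)cc4)c3=O)c(Cl)c2)c2c(N)ncnc21`, differs from compound 1 in a single place: chloro in place of fluoro on an aromatic carbon. Among the compounds with values here, no measured step involves this exact exchange. Within the data shown here, the one measured step, a 2.5-fold higher number from compound 1 to compound 2 (0.40 log units; beyond the scatter), concerns an added fluoro at a different place, so it bears only loosely on the present change. Swapping one halogen for another of similar kind is expected to move the number little, most likely within the scatter. Compound 3 is therefore estimated at 0.3 nM, with a range from 0.1 nM to 1 nM, a step of a 1.5-fold higher number from compound 1 to compound 3 (0.18 log units; within the scatter) that is expected to be small.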

Compound 3, half-maximal inhibitory concentration: 3.7 nM
For compound 3 the middle estimate is 12-fold (1.09 log units) below the measured one; the whole stated range lies below it.
By their numbers in this assay, from the lowest: compound 1; then compound 2; then compound 3.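

In this assay, exchanging one halogen for another on this aromatic carbon, ortho to a large group, proves to be far from a quiet change: chloro in place of fluoro gives a 19-fold higher number from compound 1 to compound 3 (1.27 log units; beyond the scatter) and that step is large. Going by these compounds alone, the only earlier step, a 2.5-fold higher number from compound 1 to compound 2 (0.40 log units; beyond the scatter), was modest and came from an added fluoro at a different place, so it gave no view of how strongly this position responds. The exchange changes no count of hydrogen-bond donors or acceptors and no net charge, and nothing measured here accounts for the difference.

Still open, going by these compounds, is how other groups on this carbon would read, such as hydrogen, methyl, methoxy or a nitrile, and so whether fluoro stands out here or chloro alone falls behind. Also open, on these data alone, is whether the same exchange would give a step of similar size with the extra fluoro of compound 2 in place.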